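This account rests on a few compounds, and the source may have more. Where it says the series, first, only, none or still open, it means among the compounds named here.

Measured compounds:
compound 1, `CCc1ccc(NC(=O)N[C@H](C)c2ccccc2)cc1`, 47%
compound 2, `CC(C)c1ccc(NC(=O)N[C@H](C)c2ccccc2)cc1`, 79%
compound 3, `CCCCCc1ccc(NC(=O)N[C@H](C)c2ccccc2)cc1`, 101%

In an ADME assay on the whole organism with Oryza sativa as the target, tested at 1 uM (on this read-out lower numbers stand for a stronger effect and higher numbers for a weaker effect at the one concentration tested), compound 3 stands highest of the three, so the weakest effect, with compound 2 nearest and compound 1 furthest away. Compound 4, `CC(=O)c1ccc(NC(=O)N[C@H](C)c2ccccc2)cc1`, is the next step: acetyl in place of pentyl on an aromatic carbon. The three measured steps all concern the chain on that aromatic carbon growing: a number 32 percentage points higher from compound 1 to compound 2 (beyond the scatter), a number 54 percentage points higher from compound 1 to compound 3 (beyond the scatter) and a number 22 percentage points higher from compound 2 to compound 3 (beyond the scatter). Each step towards a larger chain went up, that is towards a weaker effect. The change to compound 4 runs the other way in size, from five heavy atoms to three, which by the measured steps points downwards. Yet the entering group brings a hydrogen-bond acceptor and a double bond outside aromatic rings, and no measured compound shows what such a group does here, so the size of the step is uncertain. A downward step is expected, a number 36 percentage points lower from compound 3 to compound 4 (beyond the scatter), roughly reversing the step to compound 3 from compound 2. Compound 4 is therefore estimated at 65%, in a range from 35% to 95%.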

Compound 4, a percentage reported as activity, at one concentration (the size of the read-out at that concentration, not a potency): 93%
Beside the measured number, compound 4's estimate is 28 percentage points below it; low and high end bracket the measured number.
By their numbers in this assay, from the lowest: compound 1; then compound 2; then compounds 4 and 3 (each within the scatter of the next).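

Replacing pentyl with acetyl on this aromatic carbon in this assay gives a number 8 percentage points lower from compound 3 to compound 4 (within the scatter), so a shorter group carrying a carbonyl and a hydrogen-bond acceptor cannot be told apart here from the longer pentyl chain. Acetyl in place of isopropyl gives a number 14 percentage points higher from compound 2 to compound 4 (beyond the scatter), and acetyl in place of ethyl gives a number 46 percentage points higher from compound 1 to compound 4 (beyond the scatter), so compound 4 goes against the pattern in compounds 1, 2 and 3, where the number rose with the size of the chain, and heavy-atom count alone does not account for the numbers at this position. No measurement at hand explains why acetyl gives this result.

The compounds shown leave open whether the carbonyl matters or whether almost any group other than ethyl gives a high number here, a question that methoxy, hydroxymethyl or a simple amine on the same carbon could help to answer. They also leave open how far the number falls with something smaller than ethyl, such as methyl or plain hydrogen, and what a carboxylic acid would do at this place.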